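A few compounds are considered here, and "the series" means these few. Any claim that something is new, unique, unknown or untested is made for them only; others in the source may bear on it.

Three compounds share one core. Compound 1 `COc1ccc(OC)c(C2OC(c3cc(OC)c(OC)c(OC)c3)=NN2C(C)=O)c1` gives 0.4% in a functional assay on BGC-823 cells (Homo sapiens) for antiproliferative activity, read by MTT assay, tested at 1 uM; on this read-out lower numbers stand for a weaker effect and higher numbers for a stronger effect at the one concentration tested; compound 2 `COc1cc(C2=NN(C(C)=O)C(c3ccccc3C(F)(F)F)O2)cc(OC)c1OC` gives 31.8%; compound 3 `COc1cc(C2=NN(C(C)=O)C(c3ccc(F)cc3)O2)cc(OC)c1OC` gives -0.4%, the lowest of the three numbers, separated from compound 1 by a gap within the scatter and from compound 2 by a large gap a number 32.2 percentage points lower from compound 2 to compound 3 (beyond the scatter). Compound 4 `COc1cc(C2=NN(C(C)=O)C(c3ccc(Cl)c(Cl)c3)O2)cc(OC)c1OC` differs from compound 3 by 3,4-dichlorophenyl in place of 4-fluorophenyl on a saturated ring carbon. Among the compounds with values here, every measured step changes the same aryl group: a number 0.8 percentage points lower from compound 1 to compound 3 (within the scatter) and a number 31.4 percentage points higher from compound 1 to compound 2 (beyond the scatter) show that one replacement left the number unchanged while another raised it strongly, so no step reproduces the entering 3,4-dichlorophenyl. A modest rise is therefore expected, a number 12.4 percentage points higher from compound 3 to compound 4 (beyond the scatter), with wide uncertainty. Compound 4 is estimated at 12%, between -5% and 40%.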

Compound 4, a percentage reported as inhibition, at one concentration (the size of the read-out at that concentration, not a potency): -0.8%
Compound 4: middle estimate off by 12.8 percentage points, on the high side, and the stated range covers the measured number.
By their numbers in this assay, from the lowest: compounds 4, 3 and 1 (each within the scatter of the next); then compound 2.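

In this assay the 3,4-dichlorophenyl group reads like the earlier aryl groups: a number 0.4 percentage points lower from compound 3 to compound 4 (within the scatter) and a number 1.2 percentage points lower from compound 1 to compound 4 (within the scatter) place it with 4-fluorophenyl and 2,5-dimethoxyphenyl at this position. Only 2-(trifluoromethyl)phenyl stands apart, with a number 32.6 percentage points lower from compound 2 to compound 4 (beyond the scatter) as the clear separation, so a halogen on the phenyl ring does not by itself go with a raised number. Nothing available explains why this one group differs. Still open, on these data alone, is whether 4-(trifluoromethyl)phenyl would match compound 2, and how an amine or a carboxylic acid on the phenyl ring would read here.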